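Removing the Methyl Ether: Expecting a Weaker Compound 4

The source may hold more compounds than are shown below. What is called first, only, known or untested is meant among the compounds shown, and "the series" means these compounds.

Compound 1 `O=C(Nc1cccc(-n2cc(-c3ccncc3)c(-c3ccc(Cl)c(O)c3)n2)c1)Nc1cccc(C(F)(F)F)c1`: in a functional assay on HT-29 cells (Homo sapiens) for inhibition, read by sulforhodamine B assay, with a stated time of 48 h (on this read-out lower numbers stand for stronger inhibition of growth and higher numbers for weaker inhibition of growth), compound 1 gives > 32500 nM, which is a limit of the assay rather than a number.
Compound 2 `COc1cc(-c2nn(-c3cccc(NC(=O)Nc4cc(C(F)(F)F)cc(C(F)(F)F)c4)c3)cc2-c2ccncc2)ccc1Cl`: in this assay compound 2 gives 1610 nM.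
Compound 3 `COc1cc(-c2nn(-c3cccc(NC(=O)Nc4cccc(C(F)(F)F)c4)c3)cc2-c2ccncc2)ccc1Cl`: in this assay compound 3 gives 1870 nM.

Compound 2 holds the lowest of the two numbers shown in this assay, while compound 3 sits within the usual scatter of it, so the two cannot be told apart; the third value is a limit. Compound 4 `O=C(Nc1cccc(-n2cc(-c3ccncc3)c(-c3ccc(Cl)c(O)c3)n2)c1)Nc1cc(C(F)(F)F)cc(C(F)(F)F)c1` differs from compound 2 in one place: hydrogen in place of methyl on an oxygen on an aromatic ring.

One measured step speaks directly to this change, in the opposite direction: an at least 17-fold lower number from compound 1 to compound 3 (1.24 log units; beyond the scatter). There, adding the methyl turned a value that was only a limit into a clear number. The step of a 1.2-fold higher number from compound 2 to compound 3 (0.07 log units; within the scatter) shows that the bis(trifluoromethyl) group in compound 2 leaves the value essentially where it stands, so the methyl ether appears to carry the weight. Taking the methyl away again in compound 4 is therefore expected to raise the number strongly, by roughly a 25-fold higher number from compound 2 to compound 4 (1.40 log units; beyond the scatter), most likely back to the limit of > 32500 nM in this assay, at which 1 of the 3 values shown sits. Compound 4 is estimated at 40000 nM, with a range from 15000 nM to 150000 nM.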

Compound 4, concentration for total growth inhibition: 1870 nM
Compound 4: middle estimate off by 21-fold (1.33 log units), on the high side; the measured number lies below the stated range.
By their numbers in this assay, from the lowest: compounds 2, 3 and 4 (each within the scatter of the next). At a limit, above all of these: compound 1.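

In this assay, going from methoxy to hydroxy on the core of compound 2 gives a 1.2-fold higher number from compound 2 to compound 4 (0.07 log units; within the scatter), so on this core the methyl on the oxygen is not needed to keep the growth inhibition. Adding a trifluoromethyl group to the hydroxy compound gives an at least 17-fold lower number from compound 1 to compound 4 (1.24 log units; beyond the scatter), which shows that a hydroxy group at this position is compatible with a measurable value, and this added group has a very different effect on the two cores: the same change on two cores in this assay, a 1.2-fold higher number (0.07 log units; within the scatter) from compound 2 to compound 3 and an at least 17-fold higher number (1.24 log units; beyond the scatter) from compound 4 to compound 1, at least 14-fold (1.17 log units) apart, beyond the scatter of two such steps The methyl-for-hydrogen change therefore cannot be read as a fixed contribution of this position, since its size depends on the rest of the molecule: the same change on two cores in this assay, an at least 17-fold lower number (1.24 log units; beyond the scatter) from compound 1 to compound 3 and a 1.2-fold lower number (0.07 log units; within the scatter) from compound 4 to compound 2, at least 14-fold (1.17 log units) apart, beyond the scatter of two such steps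

For the compounds shown here, these four compounds do not show why the two changes depend on each other, as they form only one square of two changes in one cell line. On these data alone, it also remains open how this position responds to a different group on the same aromatic carbon, such as an ethoxy group with its longer chain or an amine in place of the hydroxy.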